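This account rests on a few compounds, and the source may have more. Where it says the series, first, only, none or still open, it means among the compounds named here.

Measured compounds:
compound 1, `CCCCc1ccc(S(=O)(=O)Nc2ccc3c(c2)CN(C)C3)cc1` — 5.01 nM
compound 2, `Cc1cc2c(cc1NS(=O)(=O)c1ccc(-c3ccc(Cl)cc3)cc1)CCN(C)CC2` — 15.9 nM

Of the compounds shown here, two have been measured in an assay on isolated protein for displacement of a labelled ligand from 5-hydroxytryptamine receptor 6 (Homo sapiens), read by radioligand binding; a lower number here means a stronger inhibitor, a higher number a weaker inhibitor. Compound 1 `CCCCc1ccc(S(=O)(=O)Nc2ccc3c(c2)CN(C)C3)cc1` gives 5.01 nM, the lower of the two numbers. Compound 2 `Cc1cc2c(cc1NS(=O)(=O)c1ccc(-c3ccc(Cl)cc3)cc1)CCN(C)CC2` gives 15.9 nM, and the gap from compound 1 to compound 2 lies beyond the usual scatter of repeated measurements. Among the measured compounds shown here, no pair of measured compounds differs in a single place, so no measured single-change step is available to lean on.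

Compound 3 `CCCCc1ccc(S(=O)(=O)Nc2ccc3c(c2)CNC3)cc1` has not yet been measured in this assay. It differs from compound 1 in one place: hydrogen in place of methyl on an amine nitrogen in a ring. For the measured compounds named here, with no comparable step among the measured compounds, the account can only state an expectation. The expected step of a 1.4-fold higher number from compound 1 to compound 3 (0.15 log units; within the scatter) is small and within the scatter, with no clear direction. For compound 3 the estimated value in this assay is 7 nM, with a range from 2.5 nM to 20 nM.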

Compound 3, inhibition constant: 50.1 nM
The estimate for compound 3 lay 7.2-fold (0.85 log units) below the measured number; the measured number lies above the stated range.
By their numbers in this assay, from the lowest: compound 1; then compound 2; then compound 3.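

Replacing methyl with hydrogen on the amine nitrogen in a ring gives a 10-fold higher number from compound 1 to compound 3 (1.00 log units; beyond the scatter) in this assay, so the methyl on this nitrogen matters to the number measured for the core of compound 1. The earlier compounds shown here differed in more than one place and could not isolate any single group, whereas this step, which lies beyond the usual scatter, ties a change in the number to this one position. Nothing measured here accounts for the size or direction of the step.

On these data alone, it remains open whether an ethyl or a cyclopropyl group on this nitrogen would match methyl, surpass it or fall short. As far as these compounds go, it also remains open whether the same change on the amine nitrogen of compound 2 would bring a step of similar size.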